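Swapping the Oxazole Amide for a Chlorophenyl Amide

A few compounds are considered here, and "the series" means these few. Any claim that something is new, unique, unknown or untested is made for them only; others in the source may bear on it.

Three compounds were measured in an assay on isolated protein for inhibition of histone deacetylase 4 (Homo sapiens), with a stated time of 1 h; on this read-out lower numbers stand for stronger inhibition and higher numbers for weaker inhibition:

compound 1, `O=C(COc1ccc2cc(/C=C3/SC(=O)NC3=O)ccc2c1)Nc1ccccc1`, gives 2100 nM
compound 2, `O=C(COc1ccc2cc(/C=C3/SC(=O)NC3=O)ccc2c1)Nc1cccc(C(F)(F)F)c1`, gives 2500 nM
compound 3, `Cc1cc(NC(=O)COc2ccc3cc(/C=C4/SC(=O)NC4=O)ccc3c2)no1`, gives 1700 nM

All three share the same core and differ only in the group carried on the amide-type nitrogen. Compound 3 has the lowest of the three numbers, yet its distance to the others is small: a 1.2-fold lower number from compound 1 to compound 3 (0.09 log units; within the scatter) and a 1.5-fold lower number from compound 2 to compound 3 (0.17 log units; within the scatter), both within the scatter. Likewise a 1.2-fold higher number from compound 1 to compound 2 (0.08 log units; within the scatter). So far, then, changing this group has not moved the result beyond what repeated measurements would give.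

Compound 4, `O=C(COc1ccc2cc(/C=C3/SC(=O)NC3=O)ccc2c1)Nc1cccc(Cl)c1`, is the next variant: 3-chlorophenyl in place of 5-methyl-1,2-oxazol-3-yl on an amide-type nitrogen. For the measured compounds named here, the steps that bear on it are those between compound 1 and compound 3 and between compound 2 and compound 3, since they also exchange an aromatic group on this nitrogen, and both were within the scatter. Compound 4 is therefore expected to sit close to the others, with a step of about a 1.3-fold higher number from compound 3 to compound 4 (0.11 log units; within the scatter) and no direction beyond the scatter. The estimate for compound 4 in this assay is 2200 nM, with a range from 1200 nM to 4000 nM.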

Compound 4, half-maximal inhibitory concentration: 3800 nM
Compound 4: middle estimate off by 1.7-fold (0.24 log units), on the low side; the measured number falls inside the stated range.
By their numbers in this assay, from the lowest: compounds 3, 1, 2 and 4 (each within the scatter of the next, the first and the last beyond it).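

In this assay, exchanging the group on the amide-type nitrogen now gives a step beyond the scatter, though a modest one (a 2.2-fold higher number from compound 3 to compound 4 (0.35 log units; beyond the scatter)), so this position is not wholly indifferent to the change. The size of that step depends on the pair compared: chloro in place of hydrogen (a 1.8-fold higher number from compound 1 to compound 4 (0.26 log units; within the scatter)) and chloro in place of trifluoromethyl (a 1.5-fold higher number from compound 2 to compound 4 (0.18 log units; within the scatter)) both stay within the scatter, so no effect of either swap can be claimed. The data offer no explanation for the gap between 5-methyl-1,2-oxazol-3-yl and 3-chlorophenyl.

Still open, on these data alone, is whether an amine or a carboxylic acid in place of chloro on the aromatic carbon would move the number beyond the scatter. A longer chain in place of the aromatic group on the amide-type nitrogen is equally untested in these data.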